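Flavanone series: aromatase inhibition before the deprotected analogue

This account rests on a few compounds, and the source may have more. Where it says the series, first, only, none or still open, it means among the compounds named here.

Measured compounds and their values in this assay:
compound 1 `COCOc1ccc(C(=O)/C=C/c2ccc(OCOC)c(CC=C(C)C)c2)c(O)c1` gives > 242000 nM, which is a limit of the assay and not a number.
compound 2 `COCOc1ccc(/C=C/C(=O)c2ccc(OC)cc2O)cc1CC=C(C)C` gives > 261000 nM, again a limit of the assay.
compound 3 `COCOc1ccc(C2CC(=O)c3ccc(OC)cc3O2)cc1CC=C(C)C` gives 25100 nM.

For the measured compounds named here, in an assay on isolated protein for inhibition of Aromatase (Homo sapiens) (on this read-out lower numbers stand for stronger inhibition and higher numbers for weaker inhibition), compound 3 is the only compound with a numerical value. From compound 1 to compound 2 the change is hydrogen in place of methoxy on a saturated chain carbon bound to an oxygen on an aromatic ring; the step is a step that the two limits leave unreadable from compound 1 to compound 2, as both ends sit at limits (the limit of > 242000 nM in this assay, at which 1 of the 3 values shown sits, (the limit of > 261000 nM in this assay, at which 1 of the 3 values shown sits)). The difference between the cores of compound 1 and compound 3 is not broken down here.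

Compound 4 `COc1ccc2c(c1)OC(c1ccc(OC)c(CC=C(C)C)c1)CC2=O` is not yet measured. It differs from compound 3 by hydrogen in place of methoxy on a saturated chain carbon bound to an oxygen on an aromatic ring, the same change as from compound 1 to compound 2. Since the earlier step is unreadable, the expectation rests on compound 3 alone, with its value 25100 nM. The expected step is a 1.3-fold lower number from compound 3 to compound 4 (0.10 log units; within the scatter). For compound 4 the estimate in this assay is 20000 nM, between 5000 nM and 90000 nM.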

Compound 4, half-maximal inhibitory concentration: 3670 nM
For compound 4 the middle estimate is 5.4-fold (0.74 log units) above the measured one; the measured number lies below the stated range.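

In this assay the change from methoxymethoxy to methoxy gives a 6.8-fold lower number from compound 3 to compound 4 (0.84 log units; beyond the scatter) on the core these two share. The same change on the core of compound 1 cannot be read, as both ends of that step are limits of the assay. The series therefore holds one readable instance of this change, which shows its effect on a single core and neither confirms nor refutes that the effect carries over to another.

On these data alone, whether the step holds for other groups in the same place remains open, for example an ethoxy group, a longer chain or an amine. Also open, as far as these compounds go, is how the core of compound 1 would respond to any change that gives a value rather than a limit.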